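This account rests on a few compounds, and the source may have more. Where it says the series, first, only, none or still open, it means among the compounds named here.

Working notes on the series. In a functional assay on GC-2 cells (Mus musculus) for cytotoxicity, read by MTT assay, with a stated time of 72 h (a higher number here means a weaker inhibitor, a lower number a stronger inhibitor), compound 1 (`Nc1nc(NC2CCCCC2)sc1C(=O)c1ccccc1`) gives 8200 nM and compound 2 (`Nc1nc(Nc2ccccc2)sc1C(=O)c1cccnc1`) gives 9500 nM. These two values lie within the scatter of each other, so compound 2 stands level with compound 1. Among the compounds with values here, the two structures differ in more than one place, so no measured step isolates a single change. Compound 3 (`Nc1nc(Nc2ccccc2)sc1C(=O)c1ccc(F)cc1`) has not yet been measured. Relative to compound 2, it carries 4-fluorophenyl in place of pyridin-3-yl on a carbonyl carbon. Within the data shown here, with no measured step to guide the expectation, the anchor is compound 2 at 9500 nM, and no step beyond the scatter is expected in this assay. The expected change is a 1.4-fold lower number from compound 2 to compound 3 (0.13 log units; within the scatter), which would stay within the scatter. For compound 3 the estimated value is 7000 nM, with an expected range from 2500 nM to 20000 nM.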

Compound 3, half-maximal inhibitory concentration: 17000 nM
Compound 3: the middle estimate sits 2.4-fold (0.39 log units) below what was measured; the measured number falls inside the stated range.
By their numbers in this assay, from the lowest: compounds 1, 2 and 3 (each within the scatter of the next, the first and the last beyond it).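

Within the data shown here, this is the first step that isolates a single change: in this assay, 4-fluorophenyl in place of pyridin-3-yl on a carbonyl carbon gives a 1.8-fold higher number from compound 2 to compound 3 (0.25 log units; within the scatter). The ring hetero atom and the hydrogen-bond acceptor of pyridin-3-yl leave with this change and fluorine enters, yet the step stays within the scatter, so this pair does not tell the two groups apart at this position. No measured evidence bears on this result. Still open, as far as these compounds go, is whether a different group on this carbonyl carbon, such as piperidin-4-yl or a phenyl carrying a carboxylic acid, would give a step beyond the scatter. From the compounds shown here alone, the role of the other substituent on the shared core also stays open, since compound 1 differs from compound 2 and compound 3 in more than one place.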